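Removing bromine from a non-toxic amide series

The source may hold more compounds than are shown below. What is called first, only, known or untested is meant among the compounds shown, and "the series" means these compounds.

Compound 1 `COc1ccc(-c2cnc(NC(=O)c3ccccc3F)n2C)cc1`: in a toxicity assay on THP-1 cells (Homo sapiens) for inhibition (a lower number here means that less compound is tolerated, a higher number that more compound is tolerated), compound 1 gives > 100000 nM, a limit of the assay. Compound 2 `COc1ccc(-c2cnc(NC(=O)c3ccn[nH]3)n2C)cc1`: compound 2 gives > 100000 nM, also a limit. Compound 3 `COc1ccc(-c2cnc(NC(=O)c3cccc(Br)c3)n2C)cc1`: compound 3 gives > 100000 nM, again a limit.

Compound 3 thus stands at the limit of > 100000 nM in this assay, at which 3 of the 3 values shown sit, with nothing to set it apart from the other two. The unmeasured compound 4 `COc1ccc(-c2cnc(NC(=O)c3ccccc3)n2C)cc1` differs from it by hydrogen in place of bromo on an aromatic carbon. The measured steps that touch the carbonyl-bound ring, a step that the two limits leave unreadable from compound 1 to compound 3 and a step that the two limits leave unreadable from compound 2 to compound 3, are unreadable, as is a step that the two limits leave unreadable from compound 1 to compound 2, so no size or direction can be drawn from them. With every value shown sitting at the limit, compound 4 is expected to stay there too, an estimated 100000 nM (range 50000 nM to 200000 nM), which means an expected step of a number no higher from compound 3 to compound 4 (the limit leaves the size open).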

Compound 4, half-maximal cytotoxic concentration: > 100000 nM
Compound 4: no number, only a limit; the forecaster's own chance of this, stated with the estimate: 85%; the middle value lies on the limit itself.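

In this assay, within the data shown here, compound 4 gives > 100000 nM, a limit, so no step from compound 1, compound 2 or compound 3 to compound 4 can be read. The compounds shown leave open whether the group on the carbonyl affects toxicity at all.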